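Adding an Amino Acid Amide to a Biaryl Nitrile

The source may report more compounds than this note shows. Statements on the series, on what has been measured and on what is new or still open speak of the compounds shown alone.

Compound 1 `CCOc1ccccc1-c1ccc(-c2nc3cnccc3cc2C#N)cc1` was assessed in a physicochemical assay for lipophilicity, read by HPLC, at pH 7.5 (a lower number here means a more polar compound, a higher number a more lipophilic compound), where compound 1 gives 3.8. That is the higher of the two numbers recorded so far; the other compound, compound 2 `CC[C@@H](Nc1c(C#N)c(-c2ccc(-c3cnccc3C)cc2)nc2cnccc12)C(N)=O`, gives 2 in this assay, and the gap between the two lies beyond the usual scatter of repeated measurements. Compound 3 `CCOc1ccccc1-c1ccc(-c2nc3cnccc3c(NC(COC)C(N)=O)c2C#N)cc1` has not yet been measured. It differs from compound 1 in a single place: (1-carbamoyl-2-methoxyethyl)amino in place of hydrogen on an aromatic carbon. The entering group brings two hydrogen-bond donors and three hydrogen-bond acceptors where compound 1 has only a hydrogen atom, so a move toward the lower end of the scale is expected. Among the compounds with values here, no step between two measured compounds that share this exact change exists, so the size of the expected step rests on the counted difference alone. From compound 1 to compound 3 the step is expected to be a number 1.20 log units lower from compound 1 to compound 3 (beyond the scatter), a fall clearly beyond the scatter. Compound 3 is therefore estimated at 2.6 in this assay, with a range from 2 to 3.2.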

Compound 3, distribution coefficient: 2.8
Beside the measured number, compound 3's estimate is 0.20 log units below it; the measured number falls inside the stated range.
By their numbers in this assay, from the lowest: compound 2; then compound 3; then compound 1.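

Within the data shown here, compound 3 gives the first reading of a change at this position, the aromatic carbon ortho to a cyano group and opposite the ring nitrogen. Among these compounds, there, with (1-carbamoyl-2-methoxyethyl)amino in place of hydrogen, the reading in this assay is a number 1.00 log units lower from compound 1 to compound 3 (beyond the scatter), so this single change on the core of compound 1 is enough to shift the number by more than repeated measurements would scatter, something the earlier compounds could not show because no two of them differed in only one place. Nothing measured here accounts for the size of this step.

Among the compounds shown here, the entering group combines an amino link, a primary amide and a methoxymethyl arm, and the single step cannot divide its size among those parts; a plain amino group, a methylamino group or a carboxylic acid in place of the amide at this position would begin to separate them. A longer chain ending in the same amide, or a morpholine ring at this carbon, would show whether the size of the step holds for other groups at this position.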